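This account rests on a few compounds, and the source may have more. Where it says the series, first, only, none or still open, it means among the compounds named here.

Compound 1 `COc1cccc(C(=O)n2c(-c3cn(C)c4ccccc34)nc3ccccc32)c1` gives 10200 nM in a functional assay on A549 cells (Homo sapiens) for inhibition, read by MTT assay, with a stated time of 24 h; a higher number here means a weaker inhibitor of growth, a lower number a stronger inhibitor of growth. Compound 2 `COc1cccc(C(=O)n2c(-c3cn(C)c4ccc(OC)cc34)nc3ccccc32)c1` carries methoxy in place of hydrogen on an aromatic carbon; in this assay compound 2 gives 4600 nM, a step of a 2.2-fold lower number from compound 1 to compound 2 (0.35 log units; beyond the scatter). Compound 3 `COc1ccc(C(=O)n2c(-c3cn(C)c4ccc(Br)cc34)nc3ccccc32)cc1OC` rests on a different core; how its core differs from that of compound 1 is not broken down here. In this assay compound 3 gives 3400 nM; beside compound 2 this lies within the scatter, beside compound 1 it is the lower number.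

Compound 4 `COc1cc(C(=O)n2c(-c3cn(C)c4ccc(Br)cc34)nc3ccccc32)cc(OC)c1OC` is compound 3 with methoxy in place of hydrogen on an aromatic carbon. This is the same kind of change as from compound 1 to compound 2, not the same: here the ring is not part of a fused system, and the entering group sits ortho to a methoxy group, meta to a large group and meta to a methoxy group, rather than meta to a fused ring and para to a fused ring. The step expected here is a 1.4-fold lower number from compound 3 to compound 4 (0.15 log units; within the scatter), resting on the modest size of a 2.2-fold lower number from compound 1 to compound 2 (0.35 log units; beyond the scatter) and on the different place. Compound 4 is estimated at 2400 nM in this assay, expected between 1000 nM and 6000 nM.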

Compound 4, concentration for 50% growth inhibition: 3000 nM
Compound 4: middle estimate off by 1.3-fold (0.10 log units), on the low side, within the range that was stated.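

In this assay the added methoxy gives a 1.1-fold lower number from compound 3 to compound 4 (0.05 log units; within the scatter), a step that cannot be told from the scatter. The two steps of this change on the two cores do not differ measurably: the same change on two cores in this assay, a 2.2-fold lower number (0.35 log units; beyond the scatter) from compound 1 to compound 2 and a 1.1-fold lower number (0.05 log units; within the scatter) from compound 3 to compound 4, 2.0-fold (0.29 log units) apart, within the scatter of two such steps. For the compounds shown here, this shows no conflict between the two cores, but it does not show that the change carries over, as the methoxy enters a different place in each pair and there is only one pair per core.

Still open, from the compounds shown here alone, is how the same change behaves at one and the same place on both cores. Also open, going by these compounds, is what an amine or a carboxylic acid would give in place of the entering methoxy in this assay.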